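From Phenyl to Benzyl: One Chain Carbon Added

The source may hold more compounds than are shown below. What is called first, only, known or untested is meant among the compounds shown, and "the series" means these compounds.

Compound 1, `CCOC(=O)C(C[Se]C(=O)CC)Cc1cnc(N)c(Cl)c1`, gives 2600 nM in an assay on isolated protein for inhibition of carboxypeptidase B2 (Homo sapiens), read by spectrophotometry, with stated times of 10 min and 30 min, in the presence of a further agent that is not named here; on this read-out higher numbers stand for weaker inhibition and lower numbers for stronger inhibition.
Compound 2, `CCOC(=O)C(CCCCCN)C[Se]C(=O)CC`, gives 30 nM in this assay.
Compound 3, `NCCCCCC(C[Se]C(=O)CCc1ccccc1)C(=O)O`, gives 5.3 nM in this assay.

Of the three measured compounds, compound 3 stands at the lowest number. Its distance to compound 2 lies beyond the scatter of repeated measurements, and its distance to compound 1 is larger still, so compound 3 is the strongest inhibitor among them on this read-out.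

Compound 4, `NCCCCCC(C[Se]C(=O)CCCc1ccccc1)C(=O)O`, has not yet been measured. It differs from compound 3 in one place: benzyl in place of phenyl on a saturated chain carbon, two bonds along the chain from a carbonyl carbon. For the measured compounds named here, no pair of measured compounds shows what such a one-carbon lengthening does here, so there is no measured step to lean on. The expected step of a 1.1-fold higher number from compound 3 to compound 4 (0.05 log units; within the scatter) is therefore small, close to the scatter, with no clear direction; the number of compound 4 is expected to stay near that of compound 3. On that basis compound 4 is estimated at 6 nM, with a range from 2 nM to 20 nM.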

Compound 4, half-maximal inhibitory concentration: 4.1 nM
For compound 4 the middle estimate is 1.5-fold (0.17 log units) above the measured one; measured number inside the range.
By their numbers in this assay, from the lowest: compounds 4 and 3 (each within the scatter of the next); then compound 2; then compound 1.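

Benzyl in place of phenyl on a saturated chain carbon, two bonds along the chain from a carbonyl carbon, gives a 1.3-fold lower number from compound 3 to compound 4 (0.11 log units; within the scatter) in this assay and this step lies within the scatter, so the two groups cannot be told apart at this position on this read-out. For the compounds shown here, it is the first step between compounds that differ in one place, as the earlier compounds offered only separate numbers and no such pair. Nothing available here bears on what lies behind this result.

From the compounds shown here alone, whether a still longer chain carrying the phenyl ring, or an amine or a carboxylic acid on that ring, would stay in the same range remains open. Also open, going by these compounds, is whether the same step would read alike with an ethyl ester in place of the carboxylic acid.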